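Swapping a methyl for hydrogen at two different nitrogens

This account rests on a few compounds, and the source may have more. Where it says the series, first, only, none or still open, it means among the compounds named here.

Measured compounds:
compound 1 `CNC(=S)N/N=C/c1nccc2cc(F)ccc12` — 4080 nM
compound 2 `NC(=S)N/N=C/c1nccc2cc(F)ccc12` — 5440 nM
compound 3 `CNC(=S)NN=Cc1nccc2c(NC)cccc12` — 4240 nM

All three were tested in a functional assay on MIA PaCa-2 cells (Homo sapiens) for cytotoxicity, read by luminescence, with a stated time of 72 h; on this read-out higher numbers stand for weaker inhibition and lower numbers for stronger inhibition. Compound 1 and compound 2 share one core and differ only by hydrogen in place of methyl on an amide-type nitrogen. That change gave a 1.3-fold higher number from compound 1 to compound 2 (0.12 log units; within the scatter), so the two numbers cannot be told apart with confidence.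

Compound 3 is built on a different core. How its core differs from that of compound 1 is not broken down here. In this assay compound 3 gives a number close to compound 1 and a little lower than compound 2, all three within the scatter of one another.

Compound 4 `CNC(=S)NN=Cc1nccc2c(N)cccc12` has not been measured. It differs from compound 3 by hydrogen in place of methyl on a nitrogen on an aromatic ring. Among the compounds with values here, this is the same kind of change as the one from compound 1 to compound 2, but not the same: there the methyl left an amide-type nitrogen whose other neighbour is a thiocarbonyl carbon, whereas here it leaves a nitrogen on an aromatic ring whose other neighbour is an aromatic carbon.

Within the data shown here, the one measured example of this kind of change gave a step within the scatter, so a step of about a 1.2-fold higher number from compound 3 to compound 4 (0.07 log units; within the scatter) is expected, resting on the pair from compound 1 to compound 2. For compound 4 a value of about 5000 nM is estimated in this assay, between 2500 nM and 10000 nM.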

Compound 4, concentration for 90% inhibition: 11200 nM
Beside the measured number, compound 4's estimate is 2.2-fold (0.35 log units) below it, outside the stated range (above it).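

In this assay, replacing methylamino with amino gave a 2.6-fold higher number from compound 3 to compound 4 (0.42 log units; beyond the scatter), a modest loss of inhibition that is larger than repeat measurements would usually produce. Set beside the earlier swap of methyl for hydrogen, the new step is larger on paper, yet the gap between the two steps is no greater than the scatter allows, so the data cannot separate them: the same change on two cores in this assay, a 1.3-fold higher number (0.12 log units; within the scatter) from compound 1 to compound 2 and a 2.6-fold higher number (0.42 log units; beyond the scatter) from compound 3 to compound 4, 2.0-fold (0.30 log units) apart, within the scatter of two such steps

Within the data shown here, this means the result does not show that the change behaves differently on the two cores, but nor does it show that the effect carries over faithfully, since each core offers only a single pair and the methyl leaves a different kind of nitrogen in each, an amide-type nitrogen in one and a nitrogen on an aromatic ring in the other.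

The compounds shown leave open what the same swap would do at the amide-type nitrogen on the core of compound 3, which would separate the effect of the core from the effect of the kind of nitrogen. They also leave open whether a longer chain such as ethyl, or an acetyl group, on the aromatic amine would fall nearer to compound 3 or to compound 4.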